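A Phenyl Group on the Sulfonamide Nitrogen of Compound 3

The source may report more compounds than this note shows. Statements on the series, on what has been measured and on what is new or still open speak of the compounds shown alone.

Of the compounds shown here, three sharing one core have been tested in an assay on HEK293 cells for inhibition of solute carrier family 22 member 12 (Homo sapiens); on this read-out higher numbers stand for weaker inhibition and lower numbers for stronger inhibition. Compound 1 `Oc1c(Br)cc(CSc2nnc(Br)n2Cc2ccc(Br)c3ccccc23)cc1Br` gives 119000 nM, compound 2 `O=C(CSc1nnc(Br)n1Cc1ccc(Br)c2ccccc12)NO` gives 640 nM, and compound 3 `NS(=O)(=O)CSc1nnc(Br)n1Cc1ccc(Br)c2ccccc12` gives 365000 nM, the highest of the three numbers and so the weakest inhibitor here; its nearest neighbour is reached by a 3.1-fold higher number from compound 1 to compound 3 (0.49 log units; beyond the scatter), its furthest by a 570-fold higher number from compound 2 to compound 3 (2.76 log units; beyond the scatter). Compound 4 `O=S(=O)(CSc1nnc(Br)n1Cc1ccc(Br)c2ccccc12)Nc1ccccc1` differs from compound 3 in one spot: phenyl in place of hydrogen on a sulfonamide nitrogen. Among the compounds with values here, no measured step touches the sulfonamide nitrogen; all three exchange the group on the saturated chain carbon bound to a sulfur, and a 190-fold lower number from compound 1 to compound 2 (2.27 log units; beyond the scatter) shows how widely this series can move. Lacking a guiding step, only a small change is expected for compound 4, a 2.4-fold lower number from compound 3 to compound 4 (0.39 log units; beyond the scatter), giving an estimated 150000 nM with a range from 30000 nM to 700000 nM.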

Compound 4, half-maximal inhibitory concentration: 15800 nM
Compound 4: the middle estimate sits 9.5-fold (0.98 log units) above what was measured, and the stated range ends above it.
By their numbers in this assay, from the lowest: compound 2; then compound 4; then compound 1; then compound 3.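

In this assay the sulfonamide nitrogen proves to be a sensitive position: phenyl in place of hydrogen gives a 23-fold lower number from compound 3 to compound 4 (1.36 log units; beyond the scatter) and so moves the number without any change to the group's link to the chain carbon. With phenylsulfamoyl on that carbon there is a 25-fold higher number from compound 2 to compound 4 (1.39 log units; beyond the scatter) and a 7.5-fold lower number from compound 1 to compound 4 (0.88 log units; beyond the scatter) as well, so hydroxycarbamoyl remains the stronger inhibitor and 3,5-dibromo-4-hydroxyphenyl the weaker. No evidence at hand explains the gain. Still open, on these data alone, is whether the aromatic ring itself matters or any carbon group would do, as a methyl or cyclohexyl group on that nitrogen could show.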